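Benzyloxy in Place of Hexyloxy: What Compound 4 Might Give

The source may report more compounds than this note shows. Statements on the series, on what has been measured and on what is new or still open speak of the compounds shown alone.

Compound 3 `CCCCCCOc1ccc2c(NCCN(C)C)ccnc2c1` gives 1870 nM in a functional assay on DLD-1 cells (Homo sapiens) for cytotoxicity, read by MTT assay, with a stated time of 48 h (on this read-out higher numbers stand for weaker inhibition and lower numbers for stronger inhibition), the lowest of the three numbers at hand. Compound 1 `CCCCCCOc1ccc2c(Cl)ccnc2c1` gives 2660 nM in this assay, and the step of a 1.4-fold lower number from compound 1 to compound 3 (0.15 log units; within the scatter) comes with (2-(dimethylamino)ethyl)amino in place of chloro on an aromatic carbon. Compound 2 `CCOc1ccc2c(NCCCN(C)C)ccnc2c1` gives 8540 nM in this assay; it differs from compound 3 in more than one place, so only the two values themselves can be set side by side, and the gap is beyond the scatter. Compound 4 `CN(C)CCNc1ccnc2cc(OCc3ccccc3)ccc12` has not yet been measured in this assay. It differs from compound 3 by phenyl in place of pentyl on a saturated chain carbon bound to an oxygen on an aromatic ring. Going by the values given here, none of the measured steps touches the hexyloxy group: the only measured step concerns the chloro position and was within the scatter, and no measured pair reports a change at the ether chain. Compound 4 is therefore expected to show a step of a 1.1-fold higher number from compound 3 to compound 4 (0.03 log units; within the scatter), not beyond the scatter. Compound 4 is estimated at 2000 nM, with a range from 700 nM to 6000 nM.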

Compound 4, half-maximal inhibitory concentration: 2140 nM
Compound 4: the middle estimate sits 1.1-fold (0.03 log units) below what was measured, and the stated range covers the measured number.
By their numbers in this assay, from the lowest: compounds 3, 4 and 1 (each within the scatter of the next); then compound 2.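

With phenyl in place of pentyl on a saturated chain carbon bound to an oxygen on an aromatic ring, this assay shows a 1.1-fold higher number from compound 3 to compound 4 (0.06 log units; within the scatter). Going by these compounds alone, this is the first reading at the ether chain, and it shows that hexyloxy and benzyloxy cannot be told apart here: a straight chain and a six-membered aromatic ring of carbon give values within the scatter of each other while the rest of the molecule stays the same. No measurement at hand accounts for this likeness.

The compounds shown leave open whether this position stays as undemanding with a shorter chain, a free hydroxyl or an amine in place of the benzyl group, since compound 2 carries ethoxy but differs from compound 3 in more than one place. They also leave open what a chloro or methoxy substituent on the benzyl ring would do.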